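This account rests on a few compounds, and the source may have more. Where it says the series, first, only, none or still open, it means among the compounds named here.

Measured so far in an ADME assay on HepG2 2.2.15 cells (Homo sapiens) for cytotoxicity; a lower number here means that less compound is tolerated, a higher number that more compound is tolerated:

Compound 1, `CC(C)(C)OC(=O)Nc1ncc(C(Oc2ccc(F)c(Cl)c2)c2ccc(Cl)cc2)s1`. In this assay compound 1 reaches only a limit, > 50000 nM.
Compound 2, `O=C(Nc1ncc(C(OCc2ccc(F)cc2F)c2ccccc2)s1)c1cccs1`. In this assay compound 2 is recorded as "not toxic" (no number reported), with no number given.
Compound 3, `CCCCCC(=O)Nc1ncc(C(Oc2ccc3cc(Br)ccc3c2)c2ccc(Cl)cc2)s1`. In this assay compound 3 also reaches only a limit, > 50000 nM.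

So compound 3 does not stand on a number at all: its entry is a limit of this assay, and the same is true for the other values shown, since the limit of > 50000 nM in this assay, at which 2 of the 3 values shown sit, describes where two of the three sit, and the third carries no number. There is no measured step between any two of these compounds to lean on.

Compound 4, `O=C(Nc1ncc(C(Oc2ccc3cc(Br)ccc3c2)c2ccc(Cl)cc2)s1)c1ccc(F)cc1Br`, is the next compound to go into this assay. It differs from compound 3 in one place: 2-bromo-4-fluorophenyl in place of pentyl on a carbonyl carbon. Among the measured compounds shown here, because no step between measured compounds exists here, the size of the step from compound 3 to compound 4 has to be guessed. Given that compound 3 sits at the limit described by the limit of > 50000 nM in this assay, at which 2 of the 3 values shown sit, the expectation is a step of about an at least 1.1-fold lower number from compound 3 to compound 4 (0.04 log units; that floor lies within the scatter), that is, nothing beyond the usual scatter, with the result most likely reported again as a limit. Compound 4 is therefore expected to give about 45000 nM, within a range from 15000 nM to 100000 nM.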

Compound 4, half-maximal cytotoxic concentration: > 50000 nM
Compound 4: no number, only a limit (the forecaster's own chance of this, stated with the estimate: 60%); middle value at least 1.1-fold (0.04 log units) from the limit.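

Compound 3 and compound 4 are both recorded only as limits in this assay, so no step can be read from compound 3 to compound 4. The compounds shown leave open how much of either compound the cells would tolerate, and whether 2-bromo-4-fluorophenyl in place of pentyl changes that, as the readings stop at one shared limit: the limit of > 50000 nM in this assay, at which 3 of the 4 values shown sit.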